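The source may report more compounds than this note shows. Statements on the series, on what has been measured and on what is new or still open speak of the compounds shown alone.

Of the compounds shown here, three built on one shared core have been tested in a functional assay on L02 cells (Homo sapiens) for inhibition, read by Griess assay, with stated times of 1 h and 24 h; on this read-out lower numbers stand for stronger inhibition and higher numbers for weaker inhibition. Compound 1 `C(=C/c1nc(Nc2ccccc2)c2sccc2n1)\c1ccccc1` gives only a limit, > 1000000 nM, in this assay. Compound 2 `Fc1ccc(CNc2nc(/C=C/c3ccccc3)nc3ccsc23)cc1` likewise gives only a limit, > 1000000 nM. Compound 3 `CNc1nc(/C=C/c2cc(OC)c(OC)c(OC)c2)nc2ccsc12` also gives only a limit, > 1000000 nM. All three values sit together at the limit of > 1000000 nM in this assay, at which 3 of the 3 values shown sit, so compound 3 stands at the edge of what this assay can report rather than at a measured number. Within the data shown here, the single traceable step between measured compounds, a step that the two limits leave unreadable from compound 1 to compound 2, runs from one limit to another and its size cannot be read. Compound 4 `COc1cc(/C=C/c2nc(N(C)c3ccccc3)c3sccc3n2)cc(OC)c1OC` has not been measured. It differs from compound 3 by phenyl in place of hydrogen on a nitrogen on an aromatic ring. Among the measured compounds shown here, no measured step bears on this change, and the one change made on a nitrogen on an aromatic ring gave an unreadable result, so no direction can be drawn from the data. Compound 4 is therefore expected to stay at the limit, with the estimated step of a number no higher from compound 3 to compound 4 (the limit leaves the size open) not exceeding the scatter. The expected value for compound 4 is 1000000 nM, in a range from 300000 nM to 3000000 nM.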

Compound 4, half-maximal inhibitory concentration: 767000 nM
Estimate against measurement, compound 4: 1.3-fold (0.12 log units) above; measured number inside the range.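

Among these compounds, compound 4 is the first compound here to give a number rather than a limit in this assay, which shows that this nitrogen can carry phenyl and still yield a readable value. Phenyl in place of hydrogen on this nitrogen gives an at least 1.3-fold lower number from compound 3 to compound 4 (0.11 log units; that floor lies within the scatter), so the true gap may be larger, but the floor alone does not establish a real gain. Compound 4 also remains close to the edge of what this read-out can report, where the other compounds stay: the limit of > 1000000 nM in this assay, at which 3 of the 4 values shown sit.

Still open, as far as these compounds go, is whether a different group on this nitrogen, such as an ethyl chain or a cyclohexyl ring, would also give a readable number. It is also unclear whether phenyl here would give a number with other groups elsewhere on the shared core.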